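From trifluoromethoxy to chloro on compound 3

A few compounds are considered here, and "the series" means these few. Any claim that something is new, unique, unknown or untested is made for them only; others in the source may bear on it.

Three related compounds have been examined in a functional assay on HCT-116 cells (Homo sapiens) for cytotoxicity; a higher number here means that more compound is needed for the effect, a lower number that less compound is needed. For compound 1 `CC(=O)SCC(=O)c1ccc(NC(=O)Nc2ccc(OC(F)(F)F)cc2)cc1`, the entry reads "not determined" (no result reported), so it offers no number for comparison. Compound 2 `CC(=O)SCC(=O)c1ccc(S(=O)(=O)Nc2ccc(OC(F)(F)F)cc2)cc1` gives 16100 nM. Compound 3 `CC(=O)SCC(=O)c1ccc(NS(=O)(=O)c2ccc(OC(F)(F)F)cc2)cc1` gives 8800 nM. These two numbers lie within the usual scatter of each other, so they cannot be ranked, and compound 3 stands level with compound 2.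

The next compound, compound 4 `CC(=O)SCC(=O)c1ccc(NS(=O)(=O)c2ccc(Cl)cc2)cc1`, keeps the rest of compound 3 and carries chloro in place of trifluoromethoxy on an aromatic carbon, para to a large group: chloro in place of trifluoromethoxy on an aromatic carbon. Among the measured compounds shown here, no two measured compounds differ in one place only, so the data contain no direct guide to the effect of this exchange. The expectation is therefore cautious: a change no larger than the scatter, with no firm direction. The expected change is a 1.1-fold higher number from compound 3 to compound 4 (0.06 log units; within the scatter). For compound 4, the estimated value is 10000 nM, with an expected range from 4000 nM to 25000 nM.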

Compound 4, half-maximal effective concentration: 30800 nM
Beside the measured number, compound 4's estimate is 3.1-fold (0.49 log units) below it; measured number outside the range, above it.
By their numbers in this assay, from the lowest: compounds 3, 2 and 4 (each within the scatter of the next, the first and the last beyond it).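

In this assay, among the compounds shown here, the exchange of trifluoromethoxy for chloro on this aromatic carbon gives a 3.5-fold higher number from compound 3 to compound 4 (0.54 log units; beyond the scatter) and so provides the first comparison between two compounds that differ in one place only. The step shows that the group at this position can shift the amount of compound needed for the effect, with the chloro form needing more than the trifluoromethoxy form. No measurement at hand says why the number moves in this direction.

Going by these compounds, whether other groups at this position, such as fluoro, methoxy, trifluoromethyl or a plain hydrogen, would fall nearer compound 3 or compound 4 remains open. So does whether the same exchange would produce a similar step on compound 2, where the sulfonamide linker runs the other way round.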